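Methylating a Phenol Hydroxyl in a Lactone Series

A few compounds are considered here, and "the series" means these few. Any claim that something is new, unique, unknown or untested is made for them only; others in the source may bear on it.

Compound 1 `CC1(/C=C/c2ccccc2O)C=CC(=O)O1` and compound 2 `CC1(/C=C/c2cccc(O)c2)C=CC(=O)O1` share the same atoms joined differently; how their two cores differ is not broken down here. In a functional assay on PC-3 cells (Homo sapiens) for inhibition, read by sulforhodamine B assay, with a stated time of 48 h (on this read-out higher numbers stand for weaker inhibition of growth and lower numbers for stronger inhibition of growth), compound 1 gives 112000 nM and compound 2 gives 98800 nM, two numbers that lie within the usual scatter of each other. Compound 3 `COc1ccccc1/C=C/C1(C)C=CC(=O)O1` arises from compound 1 by methyl in place of hydrogen on an oxygen on an aromatic ring, and that change produced a 3.3-fold lower number from compound 1 to compound 3 (0.52 log units; beyond the scatter); in this assay compound 3 gives 34200 nM. Compound 4 `COc1cccc(/C=C/C2(C)C=CC(=O)O2)c1` stands to compound 2 as compound 3 stands to compound 1: the change is methyl in place of hydrogen on an oxygen on an aromatic ring, the same change at the same kind of place. Because the earlier step was a 3.3-fold lower number from compound 1 to compound 3 (0.52 log units; beyond the scatter), a comparable gain is expected for compound 4, namely a 3.1-fold lower number from compound 2 to compound 4 (0.49 log units; beyond the scatter), giving an estimated 32000 nM in this assay, with a likely range from 12000 nM to 85000 nM.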

Compound 4, concentration for total growth inhibition: 31600 nM
Compound 4: middle estimate off by 1.0-fold (0.01 log units), on the high side; low and high end bracket the measured number.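

In this assay the switch from hydroxy to methoxy gives a 3.1-fold lower number from compound 2 to compound 4 (0.50 log units; beyond the scatter) and so repeats, on a second core, what the same switch did on the first. The two steps match in size, so here the change carries from one core to the other: the same change on two cores in this assay, a 3.3-fold lower number (0.52 log units; beyond the scatter) from compound 1 to compound 3 and a 3.1-fold lower number (0.50 log units; beyond the scatter) from compound 2 to compound 4, 1.0-fold (0.02 log units) apart, within the scatter of two such steps. Going by these compounds alone, this rests on only two pairs of compounds in one cell assay, so it shows neither that the change would carry to a further core nor why the numbers fall.

The compounds shown leave open whether ethyl or a longer chain on that oxygen would lower the number further. They also leave open how an amine or a carboxylic acid in that place would behave.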